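The source may report more compounds than this note shows. Statements on the series, on what has been measured and on what is new or still open speak of the compounds shown alone.

Working notes on the series. Compound 1 `COc1cccc(CN2CC=C(CCC(=O)NO)C2=O)c1` carries a methoxybenzyl group on the shared core; compound 2 `COc1cccc(CCCN2CC=C(CCC(=O)NO)C2=O)c1` and compound 3 `COc1ccc(CCCN2CC=C(CCC(=O)NO)C2=O)cc1` carry longer chains to the methoxyphenyl ring. In a functional assay on NCI-H23 cells (Homo sapiens) for antiproliferative activity (a lower number here means a stronger inhibitor of growth, a higher number a weaker inhibitor of growth), compound 1 gives 1970 nM. In this assay compound 2 gives 1170 nM and compound 3 gives 2510 nM. Compound 1 sits amid these three numbers: its gap to compound 3 is within the scatter, as is its gap to compound 2, so nothing separates the three. Compound 4 `O=C(CCC1=CCN(Cc2ccccc2)C1=O)NO` differs from compound 1 by hydrogen in place of methoxy on an aromatic carbon. Among the measured compounds shown here, no measured pair isolates this change; the values of compound 2 and compound 3 also lie within the scatter of each other. The step is therefore expected to be small, a 1.1-fold higher number from compound 1 to compound 4 (0.03 log units; within the scatter), with no direction beyond the scatter. Compound 4 is estimated at 2100 nM, range 900 nM to 5000 nM.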

Compound 4, concentration for 50% growth inhibition: 4290 nM
Beside the measured number, compound 4's estimate is 2.0-fold (0.31 log units) below it, and the stated range covers the measured number.
By their numbers in this assay, from the lowest: compounds 2, 1, 3 and 4 (each within the scatter of the next, the first and the last beyond it).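

In this assay, hydrogen in place of methoxy on this aromatic carbon, meta to a large group, gives a 2.2-fold higher number from compound 1 to compound 4 (0.34 log units; beyond the scatter). Among the compounds shown here, this is the first single-place step to lie beyond the scatter, and it is modest; of this pair, compound 1, which keeps the methoxy, is the stronger inhibitor of growth. Nothing available explains the shift. Open, on these data alone, is whether an amine or a hydroxyl on the same carbon would match methoxy, and whether the step holds with the longer chain of compound 2.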